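A few compounds are considered here, and "the series" means these few. Any claim that something is new, unique, unknown or untested is made for them only; others in the source may bear on it.

Measured so far:
- compound 1 `N#CC1=C(N)N(c2ccc(S(N)(=O)=O)cc2)C2=C(C(=O)CCC2)C1c1ccc(Cl)cc1Cl`: 65%
- compound 2 `N#CC1=C(N)N(c2ccc(S(N)(=O)=O)cc2)C2=C(C(=O)CCC2)C1c1ccco1`: 5%

In a functional assay on Ehrlich cells (Mus musculus) for antiproliferative activity, read by trypan blue exclusion, with a stated time of 2 h, tested at 50 ug/mL (a lower number here means a weaker effect, a higher number a stronger effect of the compound at the concentration tested), compound 2 gives 5%, the lower of the two numbers available. For the measured compounds named here, its only comparator is compound 1, and the single step on record, a number 60 percentage points lower from compound 1 to compound 2 (beyond the scatter), lies beyond the scatter. That step, however, concerns a different replacement, furan-2-yl in place of 2,4-dichlorophenyl, and so does not directly bear on the change at hand.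

Compound 3 `N#CC1=C(N)N(c2ccc(S(N)(=O)=O)cc2)C2=C(C(=O)CCC2)C1c1cccs1` differs from compound 2 by thiophen-2-yl in place of furan-2-yl on a saturated ring carbon. Going by the values given here, no measured step exchanges one five-membered aromatic ring with one hetero atom for another, so there is no recorded precedent for the size or direction of this change. Because a number 60 percentage points lower from compound 1 to compound 2 (beyond the scatter) arose from a change of a different kind, the step from compound 2 to compound 3 is expected to be small, a number 10 percentage points higher from compound 2 to compound 3 (within the scatter), with the number staying near the low end. Compound 3 is therefore estimated at 15% in this assay, within 3% to 40%.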

Compound 3, a percentage reported as activity, at one concentration (the size of the read-out at that concentration, not a potency): 88%
Estimate against measurement, compound 3: 73 percentage points below; measured number above the stated range.
By their numbers in this assay, from the lowest: compound 2; then compound 1; then compound 3.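

In this assay there is a number 83 percentage points higher from compound 2 to compound 3 (beyond the scatter) with the ring size, heavy atom count and counted donors and acceptors all unchanged, so the number at this saturated ring carbon turns on oxygen versus sulfur in the five-membered aromatic ring, a sensitivity the earlier pair could not show. There is also a number 23 percentage points higher from compound 1 to compound 3 (beyond the scatter) on replacing 2,4-dichlorophenyl with thiophen-2-yl, so among these three compounds a five-membered ring at this carbon can give either the lowest or the highest number. Nothing available accounts for the gap between the furan-2-yl and thiophen-2-yl compounds.

The compounds shown leave open how a thiophen-3-yl or an unsubstituted phenyl ring would read at this carbon, and whether a chlorine or methyl group on the thiophen-2-yl ring would keep the number. As far as these compounds go, with a single tested concentration, potency also remains open.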